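A few compounds are considered here, and "the series" means these few. Any claim that something is new, unique, unknown or untested is made for them only; others in the source may bear on it.

Working notes on the ester series

Three compounds share the ester core shown in compound 1 `COc1ccc(OCCCCCN2CCCC(COC(=O)c3ccccc3N3C(=O)CC(C)C3=O)C2)cc1OC` and differ only in the group at the far end of the five-carbon chain on the ring amine. In an in vitro functional assay on HEK ts201 cells for antagonist activity at Neuronal acetylcholine receptor; alpha4/beta2 (Homo sapiens), read by fluorescence and calcium flux (a lower number here means a stronger inhibitor, a higher number a weaker inhibitor), compound 1 gives 8320 nM. Compound 3 `COc1cccc(OCCCCCN2CCCC(COC(=O)c3ccccc3N3C(=O)CC(C)C3=O)C2)c1OC` carries the 2,3-dimethoxyphenoxy end and in this assay compound 3 gives 8710 nM; this is the second highest of the three numbers, close to compound 1 and separated from compound 2. Compound 2 `CC1CC(=O)N(c2ccccc2C(=O)OCC2CCCN(CCCCCc3ccccc3)C2)C1=O` has a bare phenyl at the chain end and in this assay compound 2 gives 24500 nM. Moving the two methoxy groups gave a 1.0-fold higher number from compound 1 to compound 3 (0.02 log units; within the scatter), whereas replacing the dimethoxyphenoxy end by phenyl gave a 2.9-fold higher number from compound 1 to compound 2 (0.47 log units; beyond the scatter) and the reverse step of a 2.8-fold lower number from compound 2 to compound 3 (0.45 log units; beyond the scatter).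

Compound 4 `CC1CC(=O)N(c2ccccc2C(=O)OCC2CCCN(CCCCCOc3ccccc3)C2)C1=O` keeps the ether oxygen and removes both methoxy groups: phenyl in place of 2,3-dimethoxyphenyl on an oxygen on a saturated carbon. For the measured compounds named here, no measured step isolates this exact change; compound 2 removes the oxygen as well. The loss of the methoxy groups is expected to weigh more than the retained oxygen, so a modest rise in the number, a 1.7-fold higher number from compound 3 to compound 4 (0.24 log units; within the scatter), is expected, smaller than the step to compound 2. Compound 4 is therefore estimated at 15000 nM, within 7000 nM to 35000 nM.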

Compound 4, half-maximal inhibitory concentration: 17000 nM
For compound 4 the middle estimate is 1.1-fold (0.05 log units) below the measured one; low and high end bracket the measured number.
By their numbers in this assay, from the lowest: compounds 1, 3, 4 and 2 (each within the scatter of the next, the first and the last beyond it).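

With the ether oxygen kept, the change from a dimethoxyphenyl to phenyl now reads differently according to the methoxy pattern: the 3,4-dimethoxyphenyl step is just beyond the scatter (a 2.0-fold higher number from compound 1 to compound 4 (0.31 log units; beyond the scatter)), while the 2,3-dimethoxyphenyl step stays within it (a 2.0-fold higher number from compound 3 to compound 4 (0.29 log units; within the scatter)), so any contribution of the methoxy groups at this position is small and close to the limit of what the assay resolves. For the compounds shown here, the ether oxygen alone, isolated for the first time, gives no resolved change, since phenoxy in place of phenyl also stays within the scatter (a 1.4-fold lower number from compound 2 to compound 4 (0.16 log units; within the scatter)), and the difference earlier seen between the dimethoxyphenoxy compounds and compound 2 therefore cannot be assigned to either the oxygen or the methoxy groups separately. Nothing at hand offers a reason for these small steps.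

On these data alone, whether a single methoxy group on the phenoxy ring would behave like the pair remains open, as does the effect of a stronger change at the chain end, such as a carboxylic acid or a second amine. A longer or shorter chain on the ring amine is also untested among the compounds shown, so the role of the five-carbon spacing stays unknown.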